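Capping the amino group of compound 2 with acetyl

The compounds below may be only part of what the source reports. "The series", "measured", "known", "first", "only" and "open" are said of these compounds alone.

Values so far in a functional assay on NCI-H460 cells (Homo sapiens); a lower number here means that less compound is needed, a higher number that more compound is needed for the effect
compound 1 (`COc1cc(C2OC(c3ccc(N(C)C)cc3)=NN2C(C)=O)cc(OC)c1OC`) gives 0.044 uM
compound 2 (`COc1cc(C2OC(c3ccc(N(C)C)cc3)=NN2C(=O)CN)cc(OC)c1OC`) gives 0.66 uM

Going by the values given here, of the two numbers measured so far, compound 2 holds the higher one (0.66 uM), so more of it is needed for the effect. Compound 3 (`COc1cc(C2OC(c3ccc(N(C)C)cc3)=NN2C(=O)CNC(C)=O)cc(OC)c1OC`) is compound 2 with acetyl in place of hydrogen on an amine nitrogen, which turns amino into acetamido.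

Among the compounds with values here, only one measured step bears on this change. Placing amino on a saturated chain carbon bound to a carbonyl carbon gave a large rise beyond the scatter (a 15-fold higher number from compound 1 to compound 2 (1.18 log units; beyond the scatter)). Within the data shown here, compound 3 keeps that nitrogen, but as acetamido rather than amino, and no measured compound tests this form. Given that single rise (a 15-fold higher number from compound 1 to compound 2 (1.18 log units; beyond the scatter)) in compound 2, part of it may be recovered, so a moderate move to a lower number is expected, smaller than the measured step. The expected size of this move is a 2.6-fold lower number from compound 2 to compound 3 (0.42 log units; beyond the scatter) in this assay by this estimate. The estimated value for compound 3 is 0.25 uM with an expected range of 0.05 uM to 1 uM in this assay as a working guess.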

Compound 3, concentration for half-maximal effect: 0.48 uM
Compound 3: the middle estimate sits 1.9-fold (0.28 log units) below what was measured, and the stated range covers the measured number.
By their numbers in this assay, from the lowest: compound 1; then compounds 3 and 2 (each within the scatter of the next).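

In this assay, putting acetyl on the amine nitrogen gives a 1.4-fold lower number from compound 2 to compound 3 (0.14 log units; within the scatter) and so recovers none of the lost ground beyond the scatter; at this position, amino and acetamido cannot be told apart. The gap to the plain acetyl of compound 1 therefore stays large, with an 11-fold higher number from compound 1 to compound 3 (1.04 log units; beyond the scatter) as the step, which shows that the higher number does not depend on the nitrogen remaining a free amino group. Nothing available explains why either nitrogen-bearing group needs so much more compound than the plain acetyl.

The compounds shown leave open whether the large step follows the nitrogen itself or would come with any substituent on this saturated chain carbon bound to a carbonyl carbon, as both substituents tested here carry that nitrogen. A methyl or hydroxyl group at that carbon would help separate these two readings, while a dimethylamino group or a carboxylic acid would show whether the number stays this insensitive to what is placed there.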